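A phenethyl swap on compound 1

The source may hold more compounds than are shown below. What is called first, only, known or untested is meant among the compounds shown, and "the series" means these compounds.

Values so far in an ADME assay on HepG2 cells (Homo sapiens) for cytotoxicity, in the presence of a further agent that is not named here (on this read-out lower numbers stand for stronger inhibition and higher numbers for weaker inhibition), are these:
- Compound 1 `Cn1c(Cc2ccccc2C(F)(F)F)nc(C(=O)NCc2cccnc2)c(O)c1=O` gives > 100000 nM as a limit
- Compound 2 `Cn1c(Cc2ccccc2C(F)(F)F)nc(C(=O)NCC2CCCCC2)c(O)c1=O` gives > 100000 nM as a limit
- Compound 3 `CC(c1ccccc1C(F)(F)F)c1nc(C(=O)NCc2ccccc2)c(O)c(=O)n1C` gives > 100000 nM as a limit

In this assay compound 1 stands at > 100000 nM as a limit and not as a number. The other two measured compounds offer no number either, as the limit of > 100000 nM in this assay, at which 3 of the 3 values shown sit, makes plain. The unmeasured compound 4 `Cn1c(Cc2ccccc2C(F)(F)F)nc(C(=O)CCc2ccccc2)c(O)c1=O` differs from compound 1 by phenethyl in place of ((pyridin-3-yl)methyl)amino on a carbonyl carbon. Among the compounds with values here, the one measured step bearing on this change is a step that the two limits leave unreadable from compound 1 to compound 2 and it has no readable size, so it sets no scale. With every measured compound at the limit, no step beyond the scatter is expected in this assay and no direction can be given. The expected outcome is a number no higher from compound 1 to compound 4 (the limit leaves the size open) as an estimate only. Another limit is the most likely report. For compound 4 the estimated value is 100000 nM with a range from 30000 nM to 300000 nM expected.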

Compound 4, half-maximal inhibitory concentration: > 100000 nM
Compound 4: a limit, no number; the forecaster's own chance of this, stated with the estimate: 80%; the middle value sits exactly at the limit.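

Within the data shown here, compound 4 joins compound 1 and compound 2 in giving a limit and not a number in this assay, so no step among them can be read: the limit of > 100000 nM in this assay, at which 4 of the 4 values shown sit. The compounds shown leave open whether phenethyl in place of ((pyridin-3-yl)methyl)amino on a carbonyl carbon changes the read-out at all, and in which direction.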